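This account rests on a few compounds, and the source may have more. Where it says the series, first, only, none or still open, it means among the compounds named here.

Of the compounds shown here, two have a number so far, both from a functional assay on HCT-116 cells (Homo sapiens) for cytotoxicity, read by CellTiter-Glo, with a stated time of 5 days; a lower number here means a stronger inhibitor, a higher number a weaker inhibitor. Compound 1, `COc1ccc(-n2nc(Nc3cc(C)[nH]n3)c3ccccc3c2=O)cc1`, gives 700 nM in this assay. Compound 2, `Cc1cc(Nc2nn(Cc3ccc([N+](=O)[O-])cc3)c(=O)c3ccccc23)n[nH]1`, gives 1400 nM in this assay, which is the higher of the two numbers; its nearest neighbour is compound 1, and the gap between the two lies within the scatter, so no order between them is claimed.

Compound 3, `Cc1cc(Nc2nn(CC(C)C)c(=O)c3ccccc23)n[nH]1`, has not been measured. It differs from compound 2 in one place: isopropyl in place of 4-nitrophenyl on a saturated chain carbon bound to an aromatic nitrogen. Going by the values given here, no pair of measured compounds shows this kind of change, so the effect of swapping this group on this assay is unknown from the data at hand.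

With nothing to anchor the direction, the step from compound 2 to compound 3 is estimated as small, a 1.4-fold higher number from compound 2 to compound 3 (0.15 log units; within the scatter), leaning weaker but not beyond the scatter. Compound 3 is expected to give about 2000 nM in this assay, within a range of 700 nM to 6000 nM.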

Compound 3, half-maximal inhibitory concentration: 1100 nM
Estimate against measurement, compound 3: 1.8-fold (0.26 log units) above; measured number inside the range.
By their numbers in this assay, from the lowest: compounds 1, 3 and 2 (each within the scatter of the next).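

In this assay, isopropyl in place of 4-nitrophenyl on a saturated chain carbon bound to an aromatic nitrogen gives a 1.3-fold lower number from compound 2 to compound 3 (0.10 log units; within the scatter) and isobutyl in place of 4-methoxyphenyl on an aromatic nitrogen gives a 1.6-fold higher number from compound 1 to compound 3 (0.20 log units; within the scatter) at the same place in the series. A group with no ring and no hydrogen-bond acceptors therefore stays within the scatter of both ring-bearing compounds, so a six-membered aromatic ring in this group is not needed for a number in this range. No measurement accounts for how close these numbers lie.

All steps shown lie within the scatter, so no group at this place can yet be ranked. On these data alone, whether an amine or a carboxylic acid on a longer chain, on an aromatic nitrogen, moves the number beyond the scatter remains open.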